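The compounds below may be only part of what the source reports. "The series", "measured", "known", "first", "only" and "open" are said of these compounds alone.

Notes on the series in a functional assay on cells (T-cell line, Homo sapiens) for inhibition (on this read-out lower numbers stand for stronger inhibition and higher numbers for weaker inhibition), follow. Compound 1 (`COc1ccc(CCCN2CCC(COCc3ccc(Cl)c(Cl)c3)CC2)cc1`) gives 200 nM in this read-out, compound 2 (`COc1ccc(CCCN2CCC(C(O)CC(c3ccccc3)c3ccccc3)CC2)cc1`) gives 1500 nM and compound 3 (`COc1ccccc1CCCN1CCC(COC(c2ccccc2)c2ccccc2)CC1`) gives 2400 nM on the same scale. Compound 3 lies within the scatter of compound 2, and its number is higher than that of compound 1 by a margin beyond the scatter.

Compound 4 (`CCCCCN1CCC(COC(c2ccccc2)c2ccccc2)CC1`) differs from compound 3 in one place (ethyl in place of 2-methoxyphenyl on a saturated chain carbon, three bonds along the chain from an amine nitrogen in a ring). It has ethyl in place of 2-methoxyphenyl on a saturated chain carbon, three bonds along the chain from an amine nitrogen in a ring. Within the data shown here, no measured pair shows this change, so the expectation rests on little direct evidence. A small step toward weaker inhibition is expected in this assay (a 1.7-fold higher number from compound 3 to compound 4 (0.22 log units; within the scatter)), possibly no larger than the scatter. Compound 4 is estimated at 4000 nM in this assay, with an expected range from 1000 nM to 15000 nM for this estimate, kept wide for lack of a direct comparison.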

Compound 4, half-maximal inhibitory concentration: 10800 nM
Compound 4: the middle estimate sits 2.7-fold (0.43 log units) below what was measured, within the range that was stated.
By their numbers in this assay, from the lowest: compound 1; then compounds 2 and 3 (each within the scatter of the next); then compound 4.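

In this assay, among these compounds, the first comparison that differs in one place gives a 4.5-fold higher number from compound 3 to compound 4 (0.65 log units; beyond the scatter), so the group on this saturated chain carbon, three bonds along the chain from an amine nitrogen in a ring, does affect inhibition. The change removes the six-membered aromatic ring and the hydrogen-bond acceptor together, so the step cannot be assigned to either one alone. No measurement at hand accounts for the step.

The compounds shown leave open whether a plain phenyl or a pyridyl at this place would keep the number of compound 3, which would separate the role of the ring from that of the methoxy oxygen. They also leave open how a longer alkyl chain or a terminal carboxylic acid would compare with ethyl here.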